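The source may hold more compounds than are shown below. What is called first, only, known or untested is meant among the compounds shown, and "the series" means these compounds.

Measured compounds:
compound 1 `COc1cc(C)cc(-c2c(-c3ccnc(-c4ccc(C(C)=O)cc4)c3)cnn2CC#N)c1` with 103%
compound 2 `COc1cc(C)cc(-c2nn(CC#N)cc2-c2ccnc(-c3ccc(N(C)C)cc3)c2)c1` with 109%

Both numbers come from a functional assay on TK-10 cells (Homo sapiens) for cytotoxicity, read by sulforhodamine B assay, with a stated time of 48 h, tested at 0.001 uM; a higher number here means a weaker effect of the compound at the concentration tested, a lower number a stronger effect. In this assay compound 1 gives 103% and compound 2 gives 109%; the two sit within the usual scatter of each other, so neither can be set apart from the other, and both read as essentially no effect at the concentration tested. Among the compounds with values here, no step between measured compounds that differ in one place is available.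

Compound 3 `COc1cc(C)cc(-c2c(-c3ccnc(-c4ccc(N(C)C)cc4)c3)cnn2CC#N)c1` has not yet been measured. It differs from compound 1 as follows: dimethylamino in place of acetyl on an aromatic carbon. Compound 2 carries the dimethylamino group as well, on a related core, and shows no effect beyond the scatter. The step of a number 2 percentage points higher from compound 1 to compound 3 (within the scatter) is therefore expected to be none beyond the scatter. For compound 3 the estimate is 105%, with an expected range from 90% to 120%.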

Compound 3, a percentage reported as activity, at one concentration (the size of the read-out at that concentration, not a potency): 99%
Beside the measured number, compound 3's estimate is 6 percentage points above it, and the stated range covers the measured number.
By their numbers in this assay, from the lowest: compounds 3, 1 and 2 (each within the scatter of the next).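

In this assay, dimethylamino in place of acetyl on an aromatic carbon, para to a large group, gives a number 4 percentage points lower from compound 1 to compound 3 (within the scatter). Within the data shown here, this is the first direct reading of a single exchange at this place, and at the concentration tested it does not separate the 4-acetylphenyl and 4-(dimethylamino)phenyl compounds, which share the same core. No measured evidence bears on this result.

As far as these compounds go, it remains open whether another group at this place, such as a carboxylic acid, a primary amine or a longer alkyl chain, would give a number beyond the scatter of compound 1. A single concentration at which these compounds show essentially no effect also leaves open whether acetyl and dimethylamino would differ at a higher concentration.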